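Trifluoromethyl for Methyl on the Fused Ring of Compound 2

The source may hold more compounds than are shown below. What is called first, only, known or untested is meant among the compounds shown, and "the series" means these compounds.

Measured so far:
Compound 1 `Cc1[nH]n(-c2nc3cc(-c4ccccc4)ccc3[nH]2)c(=O)c1Cc1ccccc1`: 810 nM
Compound 2 `Cc1ccc2[nH]c(-n3[nH]c(C)c(Cc4ccccc4)c3=O)nc2c1`: 670 nM
Compound 3 `Cc1ccc2[nH]c(-n3[nH]c(C)c(C)c3=O)nc2c1`: 2600 nM

All three compounds were tested in an assay on isolated protein for inhibition of alpha-ketoglutarate-dependent dioxygenase alkB homolog 3 (Homo sapiens), read by polymerase chain reaction, with a stated time of 1 h; on this read-out higher numbers stand for weaker inhibition and lower numbers for stronger inhibition. Compound 2 gives the smallest number of the three, but its gap to compound 1 is within the scatter, so the two cannot be told apart; only compound 3 stands clearly apart with a higher number.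

Compound 4 `Cc1[nH]n(-c2nc3cc(C(F)(F)F)ccc3[nH]2)c(=O)c1Cc1ccccc1` is not yet measured. It arises from compound 2 by trifluoromethyl in place of methyl on an aromatic carbon.

Two measured steps describe this series. The step of a 3.9-fold higher number from compound 2 to compound 3 (0.59 log units; beyond the scatter) concerns a different part of the molecule, the saturated chain carbon, and does not bear on the fused ring. The step of a 1.2-fold lower number from compound 1 to compound 2 (0.08 log units; within the scatter) concerns the same aromatic carbon: exchanging phenyl for methyl there left the number where it was. This position has therefore tolerated two quite different groups without a change beyond the scatter. Among the measured compounds shown here, no step with trifluoromethyl is available.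

On that basis compound 4 is expected to show no step beyond the scatter, with an estimated step of a 1.0-fold higher number from compound 2 to compound 4 (0.02 log units; within the scatter). Compound 4 is estimated at 700 nM, with a range from 250 nM to 2000 nM.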

Compound 4, half-maximal inhibitory concentration: 610 nM
Beside the measured number, compound 4's estimate is 1.1-fold (0.06 log units) above it, and the stated range covers the measured number.
By their numbers in this assay, from the lowest: compounds 4, 2 and 1 (each within the scatter of the next); then compound 3.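

In this assay, the exchange of methyl for trifluoromethyl gives a 1.1-fold lower number from compound 2 to compound 4 (0.04 log units; within the scatter), and the exchange of phenyl for trifluoromethyl gives a 1.3-fold lower number from compound 1 to compound 4 (0.12 log units; within the scatter). With methyl, phenyl and trifluoromethyl, this aromatic carbon has now carried three different groups, including one of 1 heavy atom and one of 4 heavy atoms, and no exchange among compounds 1, 2 and 4 moves the number beyond the scatter. Nothing available explains this insensitivity to the group at this position.

Going by these compounds, it remains open whether the same holds for a group of another kind on this carbon, such as an amine, a carboxylic acid or a longer chain, or for plain hydrogen there. On these data alone, it is also open whether trifluoromethyl would behave in the same way in the setting of compound 3, which gives 2600 nM and has hydrogen in place of the phenyl on the saturated chain carbon.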